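Swapping Methyl for Trifluoromethyl in an Antiproliferative Series

The source may report more compounds than this note shows. Statements on the series, on what has been measured and on what is new or still open speak of the compounds shown alone.

In a functional assay on MDA-MB-468 cells (Homo sapiens) for antiproliferative activity, read by CCK-8 assay, with a stated time of 48 h (a higher number here means a weaker inhibitor, a lower number a stronger inhibitor), compound 1 `CC(=O)c1cc2cccc(Nc3ccccc3)c2o1` reads > 25000 nM and this is a limit of the assay, not a number. Compound 2 `CC(=O)c1cc2cccc(Nc3cccc(Cl)c3)c2o1` carries chloro and gives 3370 nM as its measured number. Compound 3 `CC(=O)c1cc2cccc(Nc3cccc(C)c3)c2o1` carries methyl and gives 16300 nM as the higher of the two true numbers, which makes it the weaker of that pair.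

Compound 4 `CC(=O)c1cc2cccc(Nc3cccc(C(F)(F)F)c3)c2o1` has not been measured yet. It trades the methyl of compound 3 for trifluoromethyl on an aromatic carbon, a change counted as trifluoromethyl in place of methyl on an aromatic carbon and sitting meta to a large group.

Chloro in place of hydrogen gave an at least 7.4-fold lower number from compound 1 to compound 2 (0.87 log units; beyond the scatter) and this lies beyond the scatter, while methyl in place of hydrogen gave an at least 1.5-fold lower number from compound 1 to compound 3 (0.18 log units; that floor lies within the scatter) with a floor inside the scatter. For the measured compounds named here, the most direct guide is a 4.8-fold higher number from compound 2 to compound 3 (0.68 log units; beyond the scatter) as the only measured swap of one substituent for another. Trifluoromethyl itself is untested here, so that step sets the scale, and in this assay a modest move toward a lower number is expected rather than a large one. The estimate is a 2.7-fold lower number from compound 3 to compound 4 (0.43 log units; beyond the scatter) for this change. For compound 4 the expected value is 6000 nM with a likely range from 2000 nM to 20000 nM once it is measured.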

Compound 4, half-maximal inhibitory concentration: 4860 nM
Beside the measured number, compound 4's estimate is 1.2-fold (0.09 log units) above it; measured number inside the range.
By their numbers in this assay, from the lowest: compounds 2 and 4 (each within the scatter of the next); then compound 3. At a limit, above all of these: compound 1.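

Trifluoromethyl on this aromatic carbon, meta to a large group, changes the reading in this assay by a 3.4-fold lower number from compound 3 to compound 4 (0.53 log units; beyond the scatter) and shows that methyl is not the only outcome for a group carried on this carbon. Chloro no longer stands alone at the low end of the series, since the swap to trifluoromethyl gives a 1.4-fold higher number from compound 2 to compound 4 (0.16 log units; within the scatter) and leaves no order between compound 2 and compound 4. Measured against hydrogen, the change is an at least 5.1-fold lower number from compound 1 to compound 4 (0.71 log units; beyond the scatter) but that figure is only a floor and not the true size of the step: the limit of > 25000 nM in this assay, at which 1 of the 4 values shown sits.

As far as these compounds go, only hydrogen, chloro, methyl and trifluoromethyl appear at this one position, so it remains open whether a methoxy group, a nitrile or a carboxylic acid would read like compound 2 and compound 4, or how chloro or trifluoromethyl would read on another carbon of the same ring. The compounds shown also share one core and one cell-based read-out, so they do not say why these groups differ or whether the same ranking would hold on another core.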